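Cyclohexyl in Place of Isopropyl: Expected Stability

This account rests on a few compounds, and the source may have more. Where it says the series, first, only, none or still open, it means among the compounds named here.

Measured so far in an ADME assay for metabolic stability, read by LC-MS, with a stated time of 3 h, at pH 6.5, tested at 50 uM; a higher number here means that more of the compound is left, a lower number that less of the compound is left:
- compound 1 `CC(C)OC(=O)OCOC(=O)C1=C(S[C@@H]2CN[C@H](C(=O)Nc3cccc(C(=O)O)c3)C2)[C@H](C)[C@@H]2[C@@H]([C@@H](C)O)C(=O)N12`: > 95%
- compound 2 `C[C@@H](O)[C@H]1C(=O)N2C(C(=O)OCOC(=O)C(C)(C)C)=C(S[C@@H]3CN[C@H](C(=O)Nc4cccc(C(=O)OCOC(=O)C(C)(C)C)c4)C3)[C@H](C)[C@H]12`: > 95%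
- compound 3 `CCCOC(=O)C1=C(S[C@@H]2CN[C@H](C(=O)Nc3cccc(C(=O)OCCC)c3)C2)[C@H](C)[C@@H]2[C@@H]([C@@H](C)O)C(=O)N12`: > 95%

Each of these three values is a limit of the assay rather than a number, so compound 1 cannot be placed above or below the other two. Going by the values given here, all three measured values sit at one place, namely (the limit of > 95% in this assay, at which 3 of the 3 values shown sit), and no step between measured compounds can be read from them.

Compound 4 `C[C@@H](O)[C@H]1C(=O)N2C(C(=O)OCOC(=O)OC3CCCCC3)=C(S[C@@H]3CN[C@H](C(=O)Nc4cccc(C(=O)O)c4)C3)[C@H](C)[C@H]12` shares the core of compound 1 and differs from it in one place: cyclohexyl in place of isopropyl on an oxygen next to a carbonyl group. Nothing in the measured set shows how this assay responds to such a change, so the expectation rests only on the three values at the limit.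

The step from compound 1 to compound 4 is expected to be a step that the limit leaves unreadable from compound 1 to compound 4, which is no change beyond the usual scatter. Compound 4 is therefore estimated to give 96% in this assay, within a range from 88% to 100%, most likely again reported as a limit.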

Compound 4, percent of the compound remaining: > 95%
Compound 4 gave a limit, no number; the forecaster's own chance of this, stated with the estimate: 80%; the middle value lies beyond the limit too.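

Compound 1 and compound 4 both give a limit rather than a number, so no new step can be read between them: the limit of > 95% in this assay, at which 4 of the 4 values shown sit.

The compounds shown leave open whether cyclohexyl in place of isopropyl changes the result in this assay at all.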